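Cytotoxicity From Compound 2 to Compound 3: An Estimate

A few compounds are considered here, and "the series" means these few. Any claim that something is new, unique, unknown or untested is made for them only; others in the source may bear on it.

Compound 1 `Cc1cc(NC(=O)c2cc([N+](=O)[O-])ccc2Cl)cc(-c2nc3ccccc3s2)c1O` and compound 2 `O=C(Nc1nc(-c2ccc(Cl)cc2)cs1)c1cc([N+](=O)[O-])ccc1Cl` were examined in an ADME assay on BJ cells (Homo sapiens) for cytotoxicity, with a stated time of 72 h; on this read-out higher numbers stand for an effect only at larger amounts of compound and lower numbers for an effect already at smaller amounts. For compound 1 the read-out is a limit of the assay rather than a number, > 25000 nM. Going by the values given here, compound 2 gives 18000 nM in this assay and is therefore the only compound of the pair with a numerical value. The remaining value sits at the limit of > 25000 nM in this assay, at which 1 of the 2 values shown sits. Compound 3 `O=C(Nc1nc(-c2cccc(F)c2)cs1)c1cc([N+](=O)[O-])ccc1Cl` is not yet measured; its change from compound 2 is 3-fluorophenyl in place of 4-chlorophenyl on an aromatic carbon. Among the compounds with values here, no step between two measured compounds is available, so nothing in the data points to a shift in either direction for such a change, and the step from compound 2 to compound 3 is expected to stay within the usual scatter, a 1.1-fold higher number from compound 2 to compound 3 (0.05 log units; within the scatter). Compound 3 is estimated at 20000 nM, with a range from 9000 nM to 45000 nM.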

Compound 3, half-maximal effective concentration: 24000 nM
The estimate for compound 3 lay 1.2-fold (0.08 log units) below the measured number, within the range that was stated.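

Going by these compounds alone, this is the first step between two measured compounds that differ in one place: 3-fluorophenyl in place of 4-chlorophenyl, on the aromatic carbon next to the ring nitrogen, gives a 1.3-fold higher number from compound 2 to compound 3 (0.12 log units; within the scatter) in this assay. For this one pair, then, the position takes either group without the read-out leaving the usual scatter. Compound 1 remains at a limit of the assay rather than a number and adds no second step to compare with this one: the limit of > 25000 nM in this assay, at which 1 of the 3 values shown sits.

The step changes both the halogen atom and its place on the phenyl ring, and the compounds shown do not separate the two. On these data alone, whether an amine, a carboxylic acid or a longer chain at this position would carry the number beyond the scatter remains open.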